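A few compounds are considered here, and "the series" means these few. Any claim that something is new, unique, unknown or untested is made for them only; others in the source may bear on it.

In a functional assay on MT4 cells (Homo sapiens) for antiproliferative activity, read by MTT assay, with a stated time of 96 h (on this read-out lower numbers stand for an effect already at smaller amounts and higher numbers for an effect only at larger amounts of compound), compound 1, whose structure is `CC(=O)/C(=C/c1c(-c2ccccc2)[nH]c2ccccc12)C(=O)c1ccccc1`, gives 2000 nM. Compound 2, with the structure `O=C(/C(=C\c1c(-c2ccccc2)[nH]c2ccccc12)S(=O)(=O)c1ccccc1)c1ccccc1`, gives 3000 nM in this assay; the step of a 1.5-fold higher number from compound 1 to compound 2 (0.18 log units; within the scatter) lies within the scatter, so compound 1 and compound 2 cannot be told apart, and compound 2 simply marks one end of the two numbers shown. Compound 3, with the structure `Cc1[nH]c2ccccc2c1/C=C(\C#N)S(C)(=O)=O`, differs from both in several places. In this assay compound 3 gives > 100000 nM, which is a limit of the assay and not a number; it is the limit of > 100000 nM in this assay, at which 1 of the 3 values shown sits. Compound 4, with the structure `N#C/C(=C\c1c(-c2ccccc2)[nH]c2ccccc12)S(=O)(=O)c1ccccc1`, is not yet measured. The change from compound 2 is cyano in place of benzoyl on a double-bonded chain carbon bound to a double-bonded chain carbon and a sulfonyl sulfur. Going by the values given here, the only measured step, a 1.5-fold higher number from compound 1 to compound 2 (0.18 log units; within the scatter), concerns another group at another position and was within the scatter, so it offers little guidance for this change. Compound 3 also carries cyano, but its other differences leave that comparison open. For compound 4 in this assay the expected number is 10000 nM, within a range from 2000 nM to 60000 nM. The step this estimate means, a 3.3-fold higher number from compound 2 to compound 4 (0.52 log units; beyond the scatter), is expected to be a rise beyond the scatter.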

Compound 4, half-maximal effective concentration: 400 nM
Compound 4: the middle estimate sits 25-fold (1.40 log units) above what was measured; measured number below the stated range.
By their numbers in this assay, from the lowest: compound 4; then compounds 1 and 2 (each within the scatter of the next). At a limit, above all of these: compound 3.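

In this assay, going by these compounds alone, cyano in place of benzoyl on a double-bonded chain carbon bound to a double-bonded chain carbon and a sulfonyl sulfur gives a 7.5-fold lower number from compound 2 to compound 4 (0.88 log units; beyond the scatter), the first step here that lies beyond the scatter. Within the data shown here, the only earlier step, a 1.5-fold higher number from compound 1 to compound 2 (0.18 log units; within the scatter), concerned another group and could not show that this place responds to a change of group, or that a small group without a ring can replace a larger one carrying a ring with no loss of effect. Nothing measured here explains why the number falls.

As far as these compounds go, with a single step at this place, it remains open whether the lower number belongs to cyano itself or to the removal of benzoyl. A carboxylic acid or a methyl ester in the same place could help separate these two readings.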